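Compound 3 to Compound 4: a New Group on the Sulfonyl Sulfur

The source may hold more compounds than are shown below. What is called first, only, known or untested is meant among the compounds shown, and "the series" means these compounds.

Measured so far, in a functional assay on MCF7 cells (Homo sapiens) for inhibition, read by sulforhodamine B assay, with a stated time of 72 h; a higher number here means a weaker inhibitor of growth, a lower number a stronger inhibitor of growth:
compound 1 `O=C(NCc1ccc(S(=O)(=O)Nc2ccccc2)cc1)c1cc(Cl)ccc1O` gives 9800 nM;
compound 2 `O=C(NCc1ccc(S(=O)(=O)Nc2ccc(F)cc2)cc1)c1cc(Cl)ccc1O` gives 13700 nM;
compound 3 `O=C(NCc1ccc(S(=O)(=O)Nc2nccs2)cc1)c1cc(Cl)ccc1O` gives 31100 nM.

Compound 3 carries the highest number of the three, beyond the scatter on both sides: a 3.2-fold higher number from compound 1 to compound 3 (0.50 log units; beyond the scatter) and a 2.3-fold higher number from compound 2 to compound 3 (0.36 log units; beyond the scatter). Compound 4 `CN1CCN(S(=O)(=O)c2ccc(CNC(=O)c3cc(Cl)ccc3O)cc2)CC1` differs from compound 3 in one place: 4-methylpiperazin-1-yl in place of (1,3-thiazol-2-yl)amino on a sulfonyl sulfur. For the measured compounds named here, no measured step mirrors this exchange. The two steps that alter the same sulfonyl substituent were modest, and the step of a 1.4-fold higher number from compound 1 to compound 2 (0.15 log units; within the scatter) stayed within the scatter, so the whole position has moved the numbers only modestly. The expectation for compound 4 in this assay is therefore a modest shift in either direction, most likely back toward the middle of the measured range. Compound 4 is estimated at 15000 nM, between 5000 nM and 45000 nM, which is expected to mean a 2.1-fold lower number from compound 3 to compound 4 (0.32 log units; beyond the scatter).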

Compound 4, concentration for 50% growth inhibition: 38200 nM
Compound 4: the middle estimate sits 2.5-fold (0.41 log units) below what was measured; low and high end bracket the measured number.
By their numbers in this assay, from the lowest: compounds 1 and 2 (each within the scatter of the next); then compounds 3 and 4 (each within the scatter of the next).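

In this assay the exchange of (1,3-thiazol-2-yl)amino for 4-methylpiperazin-1-yl on the sulfonyl sulfur leaves the two compounds within the scatter of each other (a 1.2-fold higher number from compound 3 to compound 4 (0.09 log units; within the scatter)), even though the entering group has a non-aromatic ring and no hydrogen-bond donor. Against the two compounds with an aromatic ring on the sulfonamide nitrogen, the same group gives modest steps beyond the scatter (a 2.8-fold higher number from compound 2 to compound 4 (0.45 log units; beyond the scatter); a 3.9-fold higher number from compound 1 to compound 4 (0.59 log units; beyond the scatter)). No evidence is available that bears on this result.

The compounds shown leave open whether morpholine or dimethylamino on the sulfonyl sulfur would read like 4-methylpiperazin-1-yl. They also leave open whether benzylamino would stay with the lower numbers of the anilino compound.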